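Extending the Carbamate Chain of an Aryl Selenocyanate

A few compounds are considered here, and "the series" means these few. Any claim that something is new, unique, unknown or untested is made for them only; others in the source may bear on it.

Compound 1 `CCCOC(=O)Nc1ccc([Se]C#N)cc1`: 3700 nM
Compound 2 `O=C(Nc1ccc([Se][Se]c2ccc(NC(=O)Oc3ccccc3)cc2)cc1)Oc1ccccc1`: 4500 nM

Both were tested in an ADME assay on 184B5 cells (Homo sapiens) for cytotoxicity, read by MTT assay, with a stated time of 72 h; a higher number here means a weaker inhibitor of growth, a lower number a stronger inhibitor of growth. Compound 1 has the lower of the two numbers, 3700 nM, yet compound 2, at 4500 nM, sits within the scatter of it, so no real difference between them can be claimed. Compound 3 `CCCCCCOC(=O)Nc1ccc([Se]C#N)cc1` differs from compound 1 by propyl in place of hydrogen on a saturated chain carbon, three bonds along the chain from an oxygen next to a carbonyl group. Among the measured compounds shown here, no measured pair shows the effect of such a change, so any expectation rests on the change alone. A small move toward a lower number is expected, a 1.5-fold lower number from compound 1 to compound 3 (0.17 log units; within the scatter), hardly beyond the scatter. Compound 3 is thus estimated at about 2500 nM in this assay, between 800 nM and 8000 nM.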

Compound 3, concentration for 50% growth inhibition: 4600 nM
Beside the measured number, compound 3's estimate is 1.8-fold (0.26 log units) below it; measured number inside the range.
By their numbers in this assay, from the lowest: compounds 1, 2 and 3 (each within the scatter of the next).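

Propyl in place of hydrogen on this saturated chain carbon gives a 1.2-fold higher number from compound 1 to compound 3 (0.09 log units; within the scatter) in this assay. At this position, then, extending the chain from propyl to hexyl produces no difference that can be told from the scatter. No available evidence bears on this result.

As far as these compounds go, whether a longer chain than hexyl would behave the same in this assay remains open. So does the effect of an amine or a carboxylic acid at the end of the chain.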